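This account rests on a few compounds, and the source may have more. Where it says the series, first, only, none or still open, it means among the compounds named here.

Measured so far:
compound 1 `CS(=O)(=O)Nc1cccc2c1CCC2c1ncc[nH]1` — 87%
compound 2 `c1cc(-c2cn[nH]c2)c2c(c1)C(c1ncc[nH]1)CC2` — 84%

Both numbers come from a functional assay on CHO cells for agonist activity at Alpha-1A adrenergic receptor (Homo sapiens), read by FLIPR and calcium flux; on this read-out higher numbers stand for larger maximal responses and lower numbers for smaller maximal responses. Within the data shown here, the one measured step in the set is a number 3 percentage points lower from compound 1 to compound 2 (within the scatter), so the two compounds cannot be separated on this read-out. Compound 2 holds the lower of the two numbers; its nearest neighbour is compound 1, and the gap between them lies within the scatter.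

The next compound is compound 3 `CCS(=O)(=O)Nc1cccc2c1CCC2c1ncc[nH]1`, not yet measured in this assay. Relative to compound 2 the change is (ethylsulfonyl)amino in place of 1H-pyrazol-4-yl on an aromatic carbon. Among the measured compounds shown here, the only measured step that bears on this change is a number 3 percentage points lower from compound 1 to compound 2 (within the scatter), which runs in the opposite direction and stayed within the scatter. For the measured compounds named here, compound 3 also carries (ethylsulfonyl)amino where compound 1 carries methanesulfonamido, and in this assay compound 1 gives 87%; no step between compound 1 and compound 3 has been measured, so this is only what the two values show.

The step of a number 2 percentage points higher from compound 2 to compound 3 (within the scatter) is therefore expected to stay within the scatter, with no real change in direction. Compound 3 is estimated at 86%, with a range from 75% to 96%.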

Compound 3, largest response reached (Emax), in percent of the reference or control that the assay uses: 86%
Compound 3: middle estimate and measured number agree at the digits printed, within the range that was stated.
By their numbers in this assay, from the lowest: compounds 2, 3 and 1 (each within the scatter of the next).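

In this assay, (ethylsulfonyl)amino in place of 1H-pyrazol-4-yl on an aromatic carbon gives a number 2 percentage points higher from compound 2 to compound 3 (within the scatter), so this position now accepts the pyrazole ring and a second sulfonamide chain with no separable change in maximal response. The sulfonyl side also gains its first measured extension: methyl in place of hydrogen on the saturated chain carbon bound to the sulfonyl sulfur gives a number 1 percentage points lower from compound 1 to compound 3 (within the scatter), which leaves methanesulfonamido and (ethylsulfonyl)amino indistinguishable on this read-out. No measured evidence is at hand to account for this flat picture across the three compounds.

Every group shown at this aromatic carbon keeps the read-out within the scatter, so what would move it remains unknown: a carboxylic acid, a primary amine, a longer chain on the sulfonyl such as butyl, or plain hydrogen at this carbon could each behave differently. Since the values here describe the largest response reached and nothing else, any difference among these compounds in the concentration needed to reach that response also stays open.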